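Adding a Methyl Group to the Core of Compound 2

A few compounds are considered here, and "the series" means these few. Any claim that something is new, unique, unknown or untested is made for them only; others in the source may bear on it.

Compound 2, with structure `O=c1ccn(CCCCCOc2ccc(Br)cc2)c(=O)[nH]1`, gives in an ADME assay on HEL cells (Homo sapiens) for cytotoxicity (a higher number here means that more compound is tolerated, a lower number that less compound is tolerated), only a limit of the assay, > 100000 nM. Compound 1, with structure `O=c1ccn(CCCCCOc2ccccc2)c(=O)[nH]1`, likewise gives a limit in this assay, > 100000 nM. For the measured compounds named here, the only measured step, a step that the two limits leave unreadable from compound 1 to compound 2, is therefore of unreadable size, as the limit of > 100000 nM in this assay, at which 2 of the 2 values shown sit, records. Compound 3, with structure `Cc1cn(CCCCCOc2ccc(Br)cc2)c(=O)[nH]c1=O`, differs from compound 2 by methyl in place of hydrogen on an aromatic carbon. Going by the values given here, no measured step touches this change, so no shift beyond the scatter is expected, and the expected step that the limit leaves unreadable from compound 2 to compound 3 stays small. Compound 3 is estimated at 150000 nM, within 50000 nM to 400000 nM.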

Compound 3, half-maximal cytotoxic concentration: > 100000 nM
Compound 3: only a limit was reported (the forecaster's own chance of this, stated with the estimate: 85%); the middle value is on the limit's open side.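

Compound 2 and compound 3 both give only a limit in this assay, so no step between them can be read: the limit of > 100000 nM in this assay, at which 3 of the 3 values shown sit.

The compounds shown leave open the actual half-maximal cytotoxic concentration of each, and whether bromo or methyl shifts it at all.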